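Nitro-to-methoxy exchange on the aryl ketone of compound 3

The compounds below may be only part of what the source reports. "The series", "measured", "known", "first", "only" and "open" are said of these compounds alone.

Three compounds in the series have numbers in a functional assay on MDA-MB-231 cells (Homo sapiens) for antiproliferative activity, read by sulforhodamine B assay, with a stated time of 48 h; on this read-out higher numbers stand for weaker inhibition and lower numbers for stronger inhibition. Compound 1 `COc1ccc(C(=O)/C=C\Nc2ccc(-c3nc4cc(OC)c(OC)c(OC)c4s3)cc2C)cc1O` gives 12400 nM in this assay. Compound 2 `COc1ccc2nc(-c3ccc(N/C=C\C(=O)c4ccc(OC)c(O)c4)cc3)sc2c1` gives 18900 nM in this assay. Compound 3 `COc1ccc2nc(-c3ccc(N/C=C\C(=O)c4cc(OC)c(OC)c([N+](=O)[O-])c4)cc3)sc2c1` gives 7610 nM in this assay, the lowest of the three numbers. Its gap to compound 1 is within the scatter, so no order between compound 3 and compound 1 can be read from the numbers; its gap to compound 2 is beyond the scatter, so compound 3 does stand at a lower number than compound 2.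

The next compound, compound 4 `COc1ccc2nc(-c3ccc(N/C=C\C(=O)c4cc(OC)c(OC)c(OC)c4)cc3)sc2c1`, differs from compound 3 in one place: methoxy in place of nitro on an aromatic carbon. Among the measured compounds shown here, no pair of measured compounds differs in this way, so the size of the step has no measured precedent here. The group that leaves and the group that enters are both small and sit at the same aromatic carbon, and the rest of the structure is unchanged, so a step within the scatter in either direction is the expectation.

Compound 4 is accordingly expected to give 6500 nM in this assay, within a range of 1800 nM to 24000 nM. The step this estimate implies, a 1.2-fold lower number from compound 3 to compound 4 (0.07 log units; within the scatter), is expected to stay within the scatter.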

Compound 4, half-maximal inhibitory concentration: 19600 nM
Compound 4: middle estimate off by 3.0-fold (0.48 log units), on the low side; the range from low to high includes it.
By their numbers in this assay, from the lowest: compounds 3, 1, 2 and 4 (each within the scatter of the next, the first and the last beyond it).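

Among the compounds shown here, on the aryl ketone ring, at the aromatic carbon ortho to a methoxy group and meta to a large group, methoxy in place of nitro gives a 2.6-fold higher number from compound 3 to compound 4 (0.41 log units; beyond the scatter) in this assay and thus provides the first one-place comparison. The step is modest but beyond the scatter, so this carbon is not indifferent to the group it carries, even when the group that leaves and the group that enters are both small. No measurement of any property of the two groups or of the two compounds is available to account for this step.

From the compounds shown here alone, with only nitro and methoxy to compare at this carbon, it remains open where an amine, a carboxylic acid or a chlorine atom would fall relative to compound 3 and compound 4. Also open, going by these compounds, is whether the same exchange gives a step of similar size on the core of compound 1, or at the other methoxy-bearing carbons of the ring.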